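The source may report more compounds than this note shows. Statements on the series, on what has been measured and on what is new or still open speak of the compounds shown alone.

Of the compounds shown here, three have been measured: compound 1 `CCn1c(C(=O)NCCN(C)C)ccc1C(CC)(CC)c1ccc(OCC(=O)C(C)(C)C)c(C)c1`, compound 2 `CCN(CC)CCNC(=O)c1ccc(C(CC)(CC)c2ccc(OCC(O)C(C)(C)C)c(C)c2)n1CC` and compound 3 `CCn1c(C(=O)NCCN(C)C)ccc1C(CC)(CC)c1ccc(OCC(O)C(C)(C)C)c(C)c1`. In a functional assay on Caco-2 cells (Homo sapiens), read by MTT assay, with a stated time of 48 h (a lower number here means a stronger inhibitor, a higher number a weaker inhibitor), compound 1 gives 1600 nM, compound 2 gives 2310 nM and compound 3 gives 1300 nM, so compound 1 cannot be told apart from either of the others. Compound 4 `CC[C@@H](C)[C@H](NC(=O)c1ccc(C(CC)(CC)c2ccc(OCC(=O)C(C)(C)C)c(C)c2)n1CC)C(=O)O` carries 1-carboxy-2-methylbutyl in place of 2-(dimethylamino)ethyl on the amide-type nitrogen: 1-carboxy-2-methylbutyl in place of 2-(dimethylamino)ethyl on an amide-type nitrogen. Changing the (tert-butyl)carbonyl, which compound 4 keeps, gave a 1.2-fold lower number from compound 1 to compound 3 (0.09 log units; within the scatter). Placing dimethylamino for diethylamino gave a 1.8-fold lower number from compound 2 to compound 3 (0.25 log units; within the scatter), and this is the only measured step in that chain. Among the measured compounds shown here, no measured compound has a carboxy group, so the guess is loose: a higher number is expected, namely a 2.2-fold higher number from compound 1 to compound 4 (0.34 log units; beyond the scatter) in this assay. The estimate for compound 4 is 3500 nM, within an expected range of 800 nM to 15000 nM.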

Compound 4, half-maximal inhibitory concentration: 4500 nM
Compound 4: middle estimate off by 1.3-fold (0.11 log units), on the low side; the measured number falls inside the stated range.
By their numbers in this assay, from the lowest: compounds 3, 1, 2 and 4 (each within the scatter of the next, the first and the last beyond it).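

In this assay, among the compounds shown here, the amide-type nitrogen is the first place where a single change moves the number beyond the scatter: 1-carboxy-2-methylbutyl in place of 2-(dimethylamino)ethyl gives a 2.8-fold higher number from compound 1 to compound 4 (0.45 log units; beyond the scatter), a modest step. This one change removes the dimethylamino group and brings in a carboxy group and two defined stereocentres together, so their separate contributions cannot be read. No measurement at hand explains the shift.

As far as these compounds go, it remains open whether a plain 2-methylbutyl chain, without the carboxylic acid, or a methyl ester of that acid would give a number closer to compound 1 or to compound 4.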